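From a Drawn Configuration to None

The source may report more compounds than this note shows. Statements on the series, on what has been measured and on what is new or still open speak of the compounds shown alone.

Measured so far in a functional assay on B16 cells (Mus musculus) for cytotoxicity, read by MTT assay, with a stated time of 48 h; on this read-out lower numbers stand for stronger inhibition and higher numbers for weaker inhibition:
compound 1, `OCCCn1cc(-c2ccc(C(F)(F)F)cc2)nn1`: > 100000 nM
compound 2, `CC1(C)OC[C@H](Cn2cc(-c3ccc4ccccc4c3)nn2)O1`: 12000 nM

Compound 1 sits at the limit of > 100000 nM in this assay, at which 1 of the 2 values shown sits, a limit of the assay rather than a number. Among the compounds with values here, compound 2 is therefore the only compound with a measured number: in this assay compound 2 gives 12000 nM. Within the data shown here, no step between two measured compounds that differ in a single place is available, so nothing measured here tells how large a change this series tolerates.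

Compound 3, `CC1(C)OCC(Cn2cc(-c3ccc4ccccc4c3)nn2)O1`, differs from compound 2 in one respect only: the two compounds have the same atoms and bonds; at least one stereo element is drawn with a configuration in one of them and without one in the other: 1 of 1 stereo elements differ; a stereocentre at a saturated ring carbon is drawn S in compound 2 and without a configuration in compound 3. The atoms and bonds are the same. With one drawn configuration removed, the sample behind compound 3 may contain both forms at the stereocentre, of which compound 2 is one. The step from compound 2 to compound 3 is expected to be small, a 1.3-fold higher number from compound 2 to compound 3 (0.12 log units; within the scatter), and is not expected to go beyond the scatter in either direction. For compound 3 the value estimated in this assay is 16000 nM, within a range from 6000 nM to 45000 nM.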

Compound 3, half-maximal inhibitory concentration: 6600 nM
Compound 3: the middle estimate sits 2.4-fold (0.38 log units) above what was measured; low and high end bracket the measured number.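

In this assay the series now has its first step between two compounds that differ in one place: a 1.8-fold lower number from compound 2 to compound 3 (0.26 log units; within the scatter). This step gives a first measure of what the series tolerates, and at this saturated ring carbon, dropping the drawn configuration leaves the read-out within the scatter, so a sample drawn S and one drawn without a configuration cannot be told apart on this read-out. The comparison is unusually narrow, as nothing else in the structure changes and the only difference between the two is this: the fact that one of compounds 2 and 3 is drawn with a defined configuration and the other without, at the place where they differ

The compounds shown leave open how the form drawn R at that carbon would read on its own, as the sample without a drawn configuration may contain both forms and its value does not resolve them. Within the data shown here, they also leave open how far this place tolerates a real change of atoms, for instance a free diol or an amine in place of the saturated ring with its two methyl groups, since the only step available so far changes no atom or bond.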